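The source may hold more compounds than are shown below. What is called first, only, known or untested is meant among the compounds shown, and "the series" means these compounds.

Compound 1 `FC(F)(F)c1ccc(-c2ccc(-c3ccc(-c4nc5ccccc5[nH]4)cc3)cc2)cc1`, compound 2 `FC(F)(F)Oc1ccc(-c2ccc(-c3ccc(-c4nc5ccccc5[nH]4)cc3)cc2)cc1` and compound 3 `Cc1ccc2[nH]c(-c3ccc(-c4ccc(-c5ccc(C(F)(F)F)cc5)cc4)cc3)nc2c1` share a core; in a functional assay on ZR-75-1 cells (Homo sapiens) for inhibition, read by sulforhodamine B assay (on this read-out higher numbers stand for weaker inhibition of growth and lower numbers for stronger inhibition of growth), compound 1 gives 48300 nM, compound 2 gives 100000 nM and compound 3 gives 2410 nM. The change trifluoromethoxy in place of trifluoromethyl on an aromatic carbon brought a 2.1-fold higher number from compound 1 to compound 2 (0.32 log units; beyond the scatter). The core of compound 3 differs from that of compound 1 by methyl in place of hydrogen on an aromatic carbon, which brought a 20-fold lower number from compound 1 to compound 3 (1.30 log units; beyond the scatter). Compound 4 `Cc1ccc2[nH]c(-c3ccc(-c4ccc(-c5ccc(OC(F)(F)F)cc5)cc4)cc3)nc2c1` is not yet measured in this assay; it differs from compound 3 by trifluoromethoxy in place of trifluoromethyl on an aromatic carbon, the same change that was made from compound 1 to compound 2, at a place described in the same words. Within the data shown here, for compound 4 a step of about a 2.1-fold higher number from compound 3 to compound 4 (0.32 log units; beyond the scatter) is expected, resting on the single earlier step of a 2.1-fold higher number from compound 1 to compound 2 (0.32 log units; beyond the scatter). Compound 4 is therefore estimated at 5000 nM, between 1600 nM and 16000 nM.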

Compound 4, concentration for 50% growth inhibition: 2410 nM
The estimate for compound 4 lay 2.1-fold (0.32 log units) above the measured number, and the stated range covers the measured number.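

In this assay, trifluoromethoxy in place of trifluoromethyl gave no change at the digits printed from compound 3 to compound 4 (within the scatter), and the two readings of this change agree as far as the scatter can tell: the same change on two cores in this assay, a 2.1-fold higher number (0.32 log units; beyond the scatter) from compound 1 to compound 2 and no change at the digits printed (within the scatter) from compound 3 to compound 4, 2.1-fold (0.32 log units) apart, within the scatter of two such steps. Methyl in place of hydrogen gave a 41-fold lower number from compound 2 to compound 4 (1.62 log units; beyond the scatter), and this change also held across the two cores: the same change on two cores in this assay, a 20-fold lower number (1.30 log units; beyond the scatter) from compound 1 to compound 3 and a 41-fold lower number (1.62 log units; beyond the scatter) from compound 2 to compound 4, 2.1-fold (0.32 log units) apart, within the scatter of two such steps. Among these compounds, both changes therefore carried between these cores without a difference that stands beyond the scatter, but this rests on only two pairs of compounds and does not show that either change would carry to any other core.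

The compounds shown leave open whether an amine or a nitrile in place of the trifluoromethyl would behave alike. They also leave open whether a carboxylic acid in place of the methyl would bring a similar step.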